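The source may hold more compounds than are shown below. What is called first, only, known or untested is meant among the compounds shown, and "the series" means these compounds.

Compound 1 (`Cc1cc(-c2cccc(O)c2)c2ncc(CSCCc3ccccc3)n2c1`) gives 11.4 ug/mL as a number
Compound 2 (`Cc1cc(-c2ccsc2)cn2c(CSCCc3ccccc3)cnc12`) gives > 50 ug/mL as a limit

In an ADME assay on HEL cells (Homo sapiens) for cytotoxicity, with a stated time of 3 days (on this read-out higher numbers stand for lower toxicity in this test and lower numbers for higher toxicity in this test), compound 2 reads > 50 ug/mL, which is a limit of the assay and not a number. Compound 1 reads 11.4 ug/mL in this assay, the lower reading of the two and so a sign of higher toxicity in this test.

Compound 3 (`Cc1cc(-c2cccs2)cn2c(CSCCc3ccccc3)cnc12`) carries thiophen-2-yl in place of thiophen-3-yl on an aromatic carbon and keeps the same atoms, joined differently. Going by the values given here, no measured step covers this change, so no shift beyond the usual scatter is expected in this assay. The expected change is small, with a number no higher from compound 2 to compound 3 (the limit leaves the size open) estimated to stay within that scatter. The estimated value for compound 3 is 50 ug/mL, with an expected range from 20 ug/mL to 100 ug/mL and a fair chance of a report as a limit.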

Compound 3, half-maximal cytotoxic concentration: 32 ug/mL
For compound 3 the middle estimate is 1.6-fold (0.19 log units) above the measured one; low and high end bracket the measured number.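

Thiophen-2-yl in place of thiophen-3-yl on this aromatic carbon, two atoms from the ring nitrogen, gives an at least 1.5-fold lower number from compound 2 to compound 3 (0.19 log units; that floor lies within the scatter) in this assay. Compound 3 gives a true number, 32 ug/mL, so a thiophene isomer at this position now has a measured reading. Compound 2 stands at a limit of the assay, > 50 ug/mL, and because of that limit the step has only a floor, which lies within the usual scatter: the limit of > 50 ug/mL in this assay, at which 1 of the 3 values shown sits.

The compounds shown therefore leave open whether moving the attachment point of the thiophene changes the reading at all, and by how much. They also leave open how an amine or a carboxylic acid in place of thiophen-2-yl on this carbon would read in this assay.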